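This account rests on a few compounds, and the source may have more. Where it says the series, first, only, none or still open, it means among the compounds named here.

Compound 1, `CC1=C(C(=O)Nc2ccccc2Cl)C(c2ccccc2Cl)NC(=S)N1`: > 100000 nM
Compound 2, `CC1=C(C(=O)Nc2ccc(Br)cc2)C(c2ccccc2)NC(=O)N1`: > 100000 nM

Both measured compounds were tested in an ADME assay on Vero cells (Chlorocebus sabaeus) for cytotoxicity, read by XTT assay, with a stated time of 72 h; a lower number here means that less compound is tolerated, a higher number that more compound is tolerated. For compound 1 the value > 100000 nM is a limit of the assay and not a number. For compound 2 the value > 100000 nM is likewise a limit of the assay. Compound 2 thus stands at the limit of > 100000 nM in this assay, at which 2 of the 2 values shown sit, and the numbers give nothing finer about it.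

Compound 3, `CC1=C(C(=O)Nc2ccc(F)cc2)C(c2ccccc2)NC(=O)N1`, has not yet been measured. It differs from compound 2 by fluoro in place of bromo on an aromatic carbon. For the measured compounds named here, no measured pair shows what this change does. Since both measured compounds sit at the same limit, the estimated step of a number no higher from compound 2 to compound 3 (the limit leaves the size open) is expected to be none beyond the usual scatter in this assay. Compound 3 is therefore expected to come out at 100000 nM, within a range of 50000 nM to 200000 nM, and most probably again only as a limit.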

Compound 3, half-maximal cytotoxic concentration: > 100000 nM
Compound 3: a limit, no number; the forecaster's own chance of this, stated with the estimate: 80%; the middle value sits exactly at the limit.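

Compound 2 and compound 3 each give only a limit of the assay and not a number, so no step can be read between them. The compounds shown leave open at what concentration any of them harms the cells in this assay, and whether fluoro in place of bromo changes that concentration.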